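The source may hold more compounds than are shown below. What is called first, only, known or untested is meant among the compounds shown, and "the series" means these compounds.

Measured so far in a functional assay on brain (Rattus norvegicus, strain Wistar) for inhibition; on this read-out higher numbers stand for weaker inhibition and lower numbers for stronger inhibition:
- compound 1 `Cc1[nH]c(=O)n(C2CCCCC2)c1-c1ccccc1` gives 47600 nM
- compound 2 `COc1ccc(-c2c(C)[nH]c(=O)n2C2CCCCC2)cc1` gives 20400 nM
- compound 3 `CCCCCOc1ccc(-c2c(C)[nH]c(=O)n2C2CCCCC2)cc1` gives 9100 nM

Compound 3 has the lowest number of the three, and its gaps to both other compounds lie beyond the scatter. The next compound is compound 4 `CCCCCCCc1ccc(-c2c(C)[nH]c(=O)n2C2CCCCC2)cc1`, with heptyl in place of pentyloxy on an aromatic carbon.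

Among the compounds with values here, no measured step makes this exchange directly, so the evidence is indirect. Three modest steps bear on it: methoxy in place of hydrogen gave a 2.3-fold lower number from compound 1 to compound 2 (0.37 log units; beyond the scatter), pentyloxy in place of hydrogen gave a 5.2-fold lower number from compound 1 to compound 3 (0.72 log units; beyond the scatter), and extending methoxy to pentyloxy gave a 2.2-fold lower number from compound 2 to compound 3 (0.35 log units; beyond the scatter). Across these three compounds, the number falls as the group grows, and none goes against this. However, none of them shows what happens when the chain lacks the oxygen.

A small step is therefore expected in this assay, slightly downward and probably not beyond the scatter. The expected change is a 1.2-fold lower number from compound 3 to compound 4 (0.08 log units; within the scatter). For compound 4 the estimated value is 7500 nM, with an expected range from 2800 nM to 20000 nM.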

Compound 4, half-maximal inhibitory concentration: 8700 nM
For compound 4 the middle estimate is 1.2-fold (0.06 log units) below the measured one; measured number inside the range.
By their numbers in this assay, from the lowest: compounds 4 and 3 (each within the scatter of the next); then compound 2; then compound 1.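

In this assay, heptyl in place of pentyloxy on this aromatic carbon gives a 1.0-fold lower number from compound 3 to compound 4 (0.02 log units; within the scatter), so compound 3 and compound 4 cannot be told apart and a chain without the oxygen serves here as well as pentyloxy. The all-carbon chain also keeps the distance from the smaller substituents, with a 2.3-fold lower number from compound 2 to compound 4 (0.37 log units; beyond the scatter) and a 5.5-fold lower number from compound 1 to compound 4 (0.74 log units; beyond the scatter), both beyond the scatter. Nothing available bears on why the exchange leaves the number in place.

Compound 3 and compound 4 differ in chain length and in the oxygen at once, so the share of each in the result cannot be separated. On these data alone, whether the number moves further with a chain longer than heptyl, or with an amine or a carboxylic acid at the chain end, stays open.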